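The source may hold more compounds than are shown below. What is called first, only, known or untested is meant among the compounds shown, and "the series" means these compounds.

Measured compounds:
compound 1 `O=[N+]([O-])c1ccc(-c2nc(CO[C@@H]3O[C@H](CO)[C@H]4OC5(CCCC5)O[C@@H]34)no2)cc1` — 50000 nM
compound 2 `Nc1nnc(SC[C@H]2O[C@@H](OCc3noc(-c4ccc([N+](=O)[O-])cc4)n3)[C@@H]3OC4(CCCC4)O[C@@H]32)s1` — 19000 nM
compound 3 `CC1(C)O[C@H]2[C@H](OCc3noc(-c4ccc([N+](=O)[O-])cc4)n3)O[C@H](CO)[C@H]2O1` — > 100000 nM

In a functional assay on T47D cells (Homo sapiens) for antiproliferative activity, read by sulforhodamine B assay, with a stated time of 48 h (a higher number here means a weaker inhibitor of growth, a lower number a stronger inhibitor of growth), compound 1 gives 50000 nM and compound 2 gives 19000 nM. The change (5-amino-1,3,4-thiadiazol-2-yl)sulfanyl in place of hydroxy on a saturated chain carbon bound to a saturated ring carbon gives a 2.6-fold lower number from compound 1 to compound 2 (0.42 log units; beyond the scatter). In this assay compound 3 gives only a limit, > 100000 nM; it sits at the limit of > 100000 nM in this assay, at which 1 of the 3 values shown sits. The difference between the core of compound 1 and the core of compound 3 is not broken down here.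

Compound 4 `CC1(C)O[C@H]2[C@H](OCc3noc(-c4ccc([N+](=O)[O-])cc4)n3)O[C@H](CSc3nnc(N)s3)[C@H]2O1` is not yet measured. It carries the same change as the measured pair, ((5-amino-1,3,4-thiadiazol-2-yl)sulfanyl in place of hydroxy on a saturated chain carbon bound to a saturated ring carbon). Since compound 3 gives a limit and no number, the step from compound 3 to compound 4 cannot be set against a starting value; the expectation for compound 4 rests on the modest step of a 2.6-fold lower number from compound 1 to compound 2 (0.42 log units; beyond the scatter) seen in the first pair and on the core of compound 3 giving only a limit. Compound 4 is estimated at 60000 nM, a range of 20000 nM to 200000 nM, with a fair chance that it too is reported only as a limit.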

Compound 4, concentration for 50% growth inhibition: > 100000 nM
Compound 4 was reported as a limit (the forecaster's own chance of this, stated with the estimate: 45%); middle value at least 1.6-fold (0.22 log units) from the limit.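

No step can be read from compound 3 to compound 4, since both are reported only as limits: the limit of > 100000 nM in this assay, at which 2 of the 4 values shown sit. Going by these compounds, whether (5-amino-1,3,4-thiadiazol-2-yl)sulfanyl in place of hydroxy changes growth inhibition on the core of compound 3 stays open.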